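A few compounds are considered here, and "the series" means these few. Any claim that something is new, unique, unknown or untested is made for them only; others in the source may bear on it.

Measured in an ADME assay on BJ cells (Homo sapiens) for cytotoxicity, with a stated time of 72 h; on this read-out lower numbers stand for an effect already at smaller amounts and higher numbers for an effect only at larger amounts of compound:

Compound 1 `Cc1cc(NC(=O)Nc2ccccc2OC(F)(F)F)c2ccccc2n1`: > 25000 nM (a limit)
Compound 2 `CCc1ccc(NC(=O)Nc2cc(C)nc3ccccc23)cc1`: > 25000 nM (a limit)
Compound 3 `Cc1cc(NC(=O)Nc2cccc([N+](=O)[O-])c2)c2ccccc2n1`: > 25000 nM (a limit)

In this assay compound 3 gives > 25000 nM, which is a limit of the assay and not a number. The same holds across the set, as the limit of > 25000 nM in this assay, at which 3 of the 3 values shown sit, shows, so no order can be read among the three compounds.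

Compound 4 `Cc1cc(NC(=O)Nc2cccc(F)c2)c2ccccc2n1` carries fluoro in place of nitro on an aromatic carbon of a six-membered aromatic ring of carbon only, meta to a large group: fluoro in place of nitro on an aromatic carbon. Among the compounds with values here, no two measured compounds differ in one place, so no measured step guides the expectation, which rests on the limit of > 25000 nM in this assay, at which 3 of the 3 values shown sit, alone. No step beyond the scatter is expected in this assay, in either direction.

The expected a number no higher from compound 3 to compound 4 (the limit leaves the size open) is accordingly small. Compound 4 is estimated at 25000 nM, with an expected range from 12000 nM to 35000 nM.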

Compound 4, half-maximal effective concentration: > 25000 nM
Compound 4: a limit, no number (the forecaster's own chance of this, stated with the estimate: 85%); the middle value sits exactly at the limit.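

Compound 3 and compound 4 both stand at a limit in this assay, so no step can be read between them. The compounds shown leave open at what amount any of them would reach the half-maximal effect, and whether exchanging nitro for fluoro changes it.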